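From Chloro to Fluoro: Expected Cell Toxicity of Compound 3

The source may report more compounds than this note shows. Statements on the series, on what has been measured and on what is new or still open speak of the compounds shown alone.

Compound 2 `CN1CCN(CCCOc2cccc3nc(Nc4ccc(Cl)c(F)c4)ccc23)CC1` has been tested in a functional assay on cells (Panel colon (Carcinoma cell lines), Homo sapiens) for inhibition, read by sulforhodamine B assay, with a stated time of 48 h (on this read-out higher numbers stand for lower toxicity in this test and lower numbers for higher toxicity in this test), where compound 2 gives 6210 nM in this assay. Compound 1 `CN1CCN(CCCOc2cccc3nc(Nc4ccc(Cl)c(C(F)(F)F)c4)ccc23)CC1` gives 6270 nM in this assay. Among the two numbers measured compound 2 has the smaller one, yet the gap to compound 1 lies within the scatter, as the step of a 1.0-fold lower number from compound 1 to compound 2 (0.00 log units; within the scatter) tells. Compound 3 `CN1CCN(CCCOc2cccc3nc(Nc4ccc(F)c(F)c4)ccc23)CC1` has not yet been measured. Compared with compound 2 it carries fluoro in place of chloro on an aromatic carbon. Among the measured compounds shown here, no measured step matches this change directly. For the measured compounds named here, the only step known, a 1.0-fold lower number from compound 1 to compound 2 (0.00 log units; within the scatter), exchanged one group on the same phenyl ring and stayed flat. On that basis no step beyond the scatter is expected. The estimated step reads a 1.0-fold lower number from compound 2 to compound 3 (0.00 log units; within the scatter) in this assay. Compound 3 is therefore expected to give about 6200 nM in this assay, with a range from 3000 nM to 13000 nM around it.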

Compound 3, concentration lethal to 50% of the cells: 12200 nM
Compound 3: the middle estimate sits 2.0-fold (0.29 log units) below what was measured; measured number inside the range.
By their numbers in this assay, from the lowest: compounds 2, 1 and 3 (each within the scatter of the next).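

Placing fluoro where chloro stood, on the aromatic carbon ortho to a fluoro group and para to a large group, gives a 2.0-fold higher number from compound 2 to compound 3 (0.29 log units; within the scatter) in this assay, the first direct reading of this exchange at this position. The wider exchange of 4-chloro-3-(trifluoromethyl)phenyl for 3,4-difluorophenyl gives a 1.9-fold higher number from compound 1 to compound 3 (0.29 log units; within the scatter), so replacing two groups on this ring together also stays inside the scatter of this read-out. No supporting measurement bears on these results.

The compounds shown leave open whether a group other than a halogen at this position, such as a methoxy group, an amine or a nitrile, would move the number beyond the scatter. They also leave open whether a longer chain on the shared core would do so.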